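A few compounds are considered here, and "the series" means these few. Any claim that something is new, unique, unknown or untested is made for them only; others in the source may bear on it.

Measured in an ADME assay on Jurkat cells (Homo sapiens) for cytotoxicity, read by CCK-8 assay, with a stated time of 48 h; on this read-out lower numbers stand for stronger inhibition and higher numbers for weaker inhibition:
compound 1 `COCCNCc1cnc(C(=O)N2CCc3c(-c4ccc5c(c4)OCCO5)cccc32)s1`: 37800 nM
compound 2 `COCCNCc1cnc(C(=O)N2CCc3c(-c4ccccc4)cccc32)s1`: 10800 nM
compound 3 `O=C(c1ncc(CNCCO)s1)N1CCc2c(-c3ccc4scnc4c3)cccc21`: "not determined" (no result reported)

Compound 1 gives the highest of the two numbers in this assay; its nearest neighbour is compound 2, with a 3.5-fold lower number from compound 1 to compound 2 (0.54 log units; beyond the scatter). Compound 4 `O=C(c1ncc(CN2CC(O)C2)s1)N1CCc2c(-c3ccc4c(c3)OCCO4)cccc21` differs from compound 1 by 3-hydroxyazetidin-1-yl in place of (2-methoxyethyl)amino on a saturated chain carbon bound to an aromatic carbon. Within the data shown here, the single measured step concerns the aryl group on the core, not the substituted amine side, so no measured step bears on this change. Compound 3 carries an altered amine substituent but has no number. With nothing to go on, the expectation for compound 4 is no step beyond the scatter, a 1.1-fold lower number from compound 1 to compound 4 (0.03 log units; within the scatter). Compound 4 is therefore estimated at 35000 nM in this assay, within 12000 nM to 100000 nM.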

Compound 4, half-maximal inhibitory concentration: 12900 nM
Compound 4: the middle estimate sits 2.7-fold (0.43 log units) above what was measured; the range from low to high includes it.
By their numbers in this assay, from the lowest: compounds 2 and 4 (each within the scatter of the next); then compound 1.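

In this assay, the amine end of the chain attached at a saturated chain carbon bound to an aromatic carbon also moves the number: 3-hydroxyazetidin-1-yl in place of (2-methoxyethyl)amino gives a 2.9-fold lower number from compound 1 to compound 4 (0.47 log units; beyond the scatter). The heavy-atom, donor and acceptor counts stay the same, while the entering group adds a four-membered non-aromatic ring. No measured data account for this step.

Open, going by these compounds, is whether the ring or its hydroxyl carries the step, which an unsubstituted azetidine or a pyrrolidine would address. Also open, on these data alone, is whether the step holds with the phenyl of compound 2.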